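Bromo on the Core: a Step from Compound 3

The source may report more compounds than this note shows. Statements on the series, on what has been measured and on what is new or still open speak of the compounds shown alone.

The series shares one core, seen unsubstituted in compound 1 `C(=C/c1nc2ncccc2[nH]1)\c1ccccc1`. In a functional assay on HeLa cells (Homo sapiens) for antiproliferative activity, read by MTT assay, with a stated time of 72 h (a lower number here means a stronger inhibitor, a higher number a weaker inhibitor), compound 1 gives 2220 nM. Compound 2 `O=[N+]([O-])c1ccc(Cl)c(/C=C/c2nc3ncccc3[nH]2)c1` gives 45100 nM in this assay, and compound 3 `N#Cc1ccc(/C=C/c2nc3ncccc3[nH]2)cc1` gives 47100 nM there. Compound 3 thus holds the highest number of the three; its value and that of compound 2 sit within the scatter of each other, while the step of a 21-fold higher number from compound 1 to compound 3 (1.33 log units; beyond the scatter) is large.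

Compound 4 `N#Cc1ccc(/C=C/c2nc3ncc(Br)cc3[nH]2)cc1` differs from compound 3 in one place: bromo in place of hydrogen on an aromatic carbon. For the measured compounds named here, no measured step touches the core in this way; the only measured step alters the pendant aromatic ring, so it does not bear on this change. With nothing in the data to anchor a direction, the expectation for compound 4 in this assay is a step of a 1.2-fold lower number from compound 3 to compound 4 (0.07 log units; within the scatter), not beyond the scatter. Compound 4 is therefore estimated at 40000 nM, within a range of 12000 nM to 130000 nM.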

Compound 4, half-maximal inhibitory concentration: 2880 nM
Estimate against measurement, compound 4: 14-fold (1.14 log units) above, and the stated range ends above it.
By their numbers in this assay, from the lowest: compounds 1 and 4 (each within the scatter of the next); then compounds 2 and 3 (each within the scatter of the next).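

Bromo on an aromatic carbon of the six-membered aromatic ring with 1 nitrogen, two atoms from the ring nitrogen, proves to be a sensitive change in this assay: the result is a 16-fold lower number from compound 3 to compound 4 (1.21 log units; beyond the scatter), and this is the only measured step that touches the shared core. The earlier compounds shown here showed a response only on the pendant aromatic ring, in a 21-fold higher number from compound 1 to compound 3 (1.33 log units; beyond the scatter), whereas this step shows that the core responds as well, with the number moving the other way. The data at hand offer no measurement that accounts for the size of this step.

From the compounds shown here alone, it remains open whether bromo at this carbon would move the number in the same way on compound 1, which lacks the cyano group. Going by these compounds, it is also open whether the step is particular to bromo or would also follow from chloro, methyl or an amine at the same carbon.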